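The source may report more compounds than this note shows. Statements on the series, on what has been measured and on what is new or still open speak of the compounds shown alone.

Three related compounds have been tested in a functional assay on MDA-MB-231 cells (Homo sapiens) for cytotoxicity, read by MTT assay, with a stated time of 72 h (on this read-out lower numbers stand for stronger inhibition and higher numbers for weaker inhibition), and a fourth awaits testing. Compound 1 `COc1cc2c(Oc3ccc(NC(=O)c4nn(-c5ccc(Br)cc5)c(=O)c5ccccc45)cc3F)ccnc2cc1OCCCN1CCN(C)CC1` gives 1370 nM in this assay. Compound 2 `COc1cc2c(Oc3ccc(NC(=O)c4nn(-c5ccccc5Br)c(=O)c5ccccc45)cc3F)ccnc2cc1OCCCN1CCN(C)CC1` differs from compound 1 only at one end of the molecule: 2-bromophenyl in place of 4-bromophenyl on an aromatic nitrogen. In this assay compound 2 gives 1680 nM, and the step is a 1.2-fold higher number from compound 1 to compound 2 (0.09 log units; within the scatter), so this change has, in one pair, made no difference that the assay can resolve. Compound 3 `COc1cc2c(Oc3ccc(NC(=O)c4nn(-c5ccc(Br)cc5)c(=O)c5ccccc45)cc3F)ccnc2cc1OCCCN1CCC(C)CC1` keeps the 4-bromophenyl of compound 1 but carries a changed group at the far end of the chain, and in this assay compound 3 gives 1160 nM, a step of a 1.2-fold lower number from compound 1 to compound 3 (0.07 log units; within the scatter).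

Compound 4 `COc1cc2c(Oc3ccc(NC(=O)c4nn(-c5ccccc5Br)c(=O)c5ccccc45)cc3F)ccnc2cc1OCCCN1CCC(C)CC1` has not yet been measured. It stands to compound 3 as compound 2 stands to compound 1: 2-bromophenyl in place of 4-bromophenyl on an aromatic nitrogen. The surroundings of the altered position are described identically in both pairs, so this is the same change, made on a second core. The two cores differ by 4-methylpiperidin-1-yl in place of 4-methylpiperazin-1-yl on a saturated chain carbon, three bonds along the chain from an oxygen on an aromatic ring.

The one measured instance of this change is within the scatter, and nothing among these compounds suggests the chain end alters its effect. Compound 4 is therefore expected to differ from compound 3 by roughly a 1.2-fold higher number from compound 3 to compound 4 (0.08 log units; within the scatter), because of a 1.2-fold higher number from compound 1 to compound 2 (0.09 log units; within the scatter) seen between compound 1 and compound 2. Compound 4 is estimated at about 1400 nM, most likely between 750 nM and 2600 nM.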

Compound 4, half-maximal inhibitory concentration: 1240 nM
Beside the measured number, compound 4's estimate is 1.1-fold (0.05 log units) above it; low and high end bracket the measured number.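

In this assay, 2-bromophenyl in place of 4-bromophenyl on the core of compound 3 gives a 1.1-fold higher number from compound 3 to compound 4 (0.03 log units; within the scatter), and 4-methylpiperidin-1-yl in place of 4-methylpiperazin-1-yl at the chain end, with 2-bromophenyl kept, gives a 1.4-fold lower number from compound 2 to compound 4 (0.13 log units; within the scatter). Neither change has an effect this assay can resolve on either core, so the near-absence of an effect carries over, but this does not show that a change with a clear effect would also transfer from one core to another, and the bromine swap behaves alike on both cores: the same change on two cores in this assay, a 1.2-fold higher number (0.09 log units; within the scatter) from compound 1 to compound 2 and a 1.1-fold higher number (0.03 log units; within the scatter) from compound 3 to compound 4, 1.1-fold (0.06 log units) apart, within the scatter of two such steps. The chain-end swap likewise looks the same whichever bromophenyl is present: the same change on two cores in this assay, a 1.2-fold lower number (0.07 log units; within the scatter) from compound 1 to compound 3 and a 1.4-fold lower number (0.13 log units; within the scatter) from compound 2 to compound 4, 1.1-fold (0.06 log units) apart, within the scatter of two such steps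

The compounds shown leave open whether other groups on the aromatic nitrogen, such as 3-bromophenyl, 4-chlorophenyl or plain phenyl, would produce a step large enough to be resolved. They also leave open whether a morpholine or a dimethylamine at the end of the chain, or a shorter or longer chain, would do so, and whether any such step would then repeat on a second core.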